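The source may hold more compounds than are shown below. What is called first, only, known or untested is meant among the compounds shown, and "the series" means these compounds.

Within the data shown here, compound 2 `C=C1CC[C@@H]2[C@](C)(CNCc3ccco3)[C@H](O)CC[C@@]2(C)[C@@H]1/C=C/C1=CCOC1=O` gives 1830 nM in a functional assay on BMMC cells (Mus musculus, strain C57BL/6) for inhibition, with stated times of 5 days and 48 h (a higher number here means a weaker inhibitor, a lower number a stronger inhibitor), the highest of the two numbers so far. Compound 1 `C=C1CC[C@@H]2[C@](C)(CNCc3ccc(C)cc3)[C@H](O)CC[C@@]2(C)[C@@H]1/C=C/C1=CCOC1=O` gives 740 nM in this assay. Among the measured compounds shown here, the one measured step, a 2.5-fold higher number from compound 1 to compound 2 (0.39 log units; beyond the scatter), shows that a six-membered aromatic ring on that chain carbon gave a lower number than furan-2-yl. Compound 3 `C=C1CC[C@@H]2[C@](C)(CNCc3ccc4c(c3)CC=N4)[C@H](O)CC[C@@]2(C)[C@@H]1/C=C/C1=CCOC1=O` differs from compound 2 by a group of 9 heavy atoms (8 carbon, 1 nitrogen; one five-membered non-aromatic ring with 1 hetero atom, one six-membered aromatic ring of carbon only) in place of a group of 5 heavy atoms (4 carbon, 1 oxygen; one five-membered aromatic ring with 1 hetero atom), on a saturated chain carbon bound to an amine nitrogen. For the measured compounds named here, since the entering group again carries a six-membered aromatic ring of carbon only, a modest lowering in this assay is expected, a 2.0-fold lower number from compound 2 to compound 3 (0.31 log units; beyond the scatter), though no direct step covers it. Compound 3 is estimated at 900 nM, between 300 nM and 2700 nM.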

Compound 3, half-maximal inhibitory concentration: 550 nM
Compound 3: the middle estimate sits 1.6-fold (0.21 log units) above what was measured; measured number inside the range.
By their numbers in this assay, from the lowest: compounds 3 and 1 (each within the scatter of the next); then compound 2.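

In this assay, at the saturated chain carbon bound to an amine nitrogen, replacing furan-2-yl with the larger two-ring group gives a 3.3-fold lower number from compound 2 to compound 3 (0.52 log units; beyond the scatter). Replacing 4-methylphenyl with that same group gives a 1.3-fold lower number from compound 1 to compound 3 (0.13 log units; within the scatter). The two compounds carrying a six-membered aromatic ring of carbon only thus stay level, and the added five-membered non-aromatic ring moves the number no further than the scatter. Open, going by these compounds, is what a pyridine ring or a carboxylic acid on that chain carbon would give in this assay. No measurement at hand gives a reason for these steps.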